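Notes on the aryl exchange from compound 2 to compound 3

The compounds below may be only part of what the source reports. "The series", "measured", "known", "first", "only" and "open" are said of these compounds alone.

Measured so far:
compound 1, `CC(C)(N)C(=O)N[C@H](COCc1cc(Cl)cc(Cl)c1)c1nnnn1CCOC(=O)NCCCCO`, 6.75 nM
compound 2, `CC(C)(N)C(=O)N[C@H](COCc1cccc(OC(F)(F)F)c1)c1nnnn1CCOC(=O)NCCCCO`, 3.1 nM

Among the compounds with values here, in a functional assay on cells for inhibition of growth hormone secretagogue receptor type 1 (Homo sapiens), read by FLIPR and calcium flux (on this read-out higher numbers stand for an effect only at larger amounts of compound and lower numbers for an effect already at smaller amounts), compound 2 stands lowest of the two numbers; the only measured step, a 2.2-fold lower number from compound 1 to compound 2 (0.34 log units; beyond the scatter), is beyond the scatter but modest. Compound 3, `CC(C)(N)C(=O)N[C@H](COCc1ccccc1C#N)c1nnnn1CCOC(=O)NCCCCO`, differs from compound 2 by 2-cyanophenyl in place of 3-(trifluoromethoxy)phenyl on a saturated chain carbon bound to an oxygen on a saturated carbon. Within the data shown here, the single step from compound 1 to compound 2 bears on this change insofar as it also exchanges the aryl group on the same saturated chain carbon, and it was modest in size. Among the measured compounds shown here, no measured pair covers a cyanophenyl or a move of the substituent around the ring, so the direction is uncertain. A step of roughly the size seen between compound 1 and compound 2 is expected, more likely towards a higher number than a lower one. Compound 3 is therefore estimated at 6 nM in this assay, with a range from 2 nM to 20 nM, which means an expected step of a 1.9-fold higher number from compound 2 to compound 3 (0.29 log units; within the scatter).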

Compound 3, half-maximal effective concentration: 1.26 nM
Compound 3: middle estimate off by 4.8-fold (0.68 log units), on the high side; measured number outside the range, below it.
By their numbers in this assay, from the lowest: compound 3; then compound 2; then compound 1.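

In this assay, the aryl group on a saturated chain carbon bound to an oxygen on a saturated carbon does not need a chlorine- or fluorine-bearing substituent: 2-cyanophenyl gives a 2.5-fold lower number from compound 2 to compound 3 (0.39 log units; beyond the scatter) against 3-(trifluoromethoxy)phenyl, and a 5.4-fold lower number from compound 1 to compound 3 (0.73 log units; beyond the scatter) against 3,5-dichlorophenyl. The smaller entering group, with 8 heavy atoms, thus gives the lowest number of the three compounds. Nothing on hand accounts for these steps.

Going by these compounds, it remains open whether the nitrile itself or its place on the ring drives the change, which a plain phenyl ring would begin to test. Also open, on these data alone, is how a carboxylic acid or an aminomethyl group would read in place of the nitrile in this assay.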